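A ring swap on a shared core

The source may hold more compounds than are shown below. What is called first, only, known or untested is meant among the compounds shown, and "the series" means these compounds.

Within the data shown here, in a physicochemical assay for lipophilicity (a lower number here means a more polar compound, a higher number a more lipophilic compound), compound 1 (`Cc1nc(-c2cc(C(F)(F)F)ccc2[C@H]2CCOc3cc(S(=O)(=O)Nc4nccs4)ccc32)co1`) gives 2.9 and compound 3 (`O=C1COCCN1c1cc(C(F)(F)F)ccc1[C@H]1CCOc2cc(S(=O)(=O)Nc3nccs3)ccc21`) gives 1.8 as the lower of the only two numbers available. For compound 2 (`O=S(=O)(Nc1nccs1)c1ccc2c(c1)OCC[C@H]2c1ccc(C(F)(F)F)cc1-c1ccc(F)nc1`) the entry reads "not determined" (no result reported) so it offers no comparison.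

The next structure is compound 4 (`O=S(=O)(Nc1nccs1)c1ccc2c(c1)OCC[C@@H]2c1ccc(C(F)(F)F)cc1-c1ccc(F)nc1`). Relative to compound 3, 6-fluoropyridin-3-yl takes the place of 3-oxomorpholin-4-yl on an aromatic carbon, ortho to a large group and meta to a trifluoromethyl group (6-fluoropyridin-3-yl in place of 3-oxomorpholin-4-yl on an aromatic carbon).

Among the measured compounds shown here, only one measured step bears on this change. It is a number 1.10 log units lower from compound 1 to compound 3 (beyond the scatter) and it comes from 3-oxomorpholin-4-yl taking the place of 2-methyl-1,3-oxazol-4-yl on an aromatic carbon. Compound 4 loses the same 3-oxomorpholin-4-yl and gains an aromatic ring, as compound 1 carries, so that large step read in reverse is the best available guide. For the measured compounds named here, no measurement yet covers 6-fluoropyridin-3-yl on its own, which leaves the comparison approximate. The expected change is estimated as a number 1.20 log units higher from compound 3 to compound 4 (beyond the scatter) and it points upward. Compound 4 is estimated at 3 with an expected range from 2.5 to 3.5 in this assay once it is measured.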

Compound 4, distribution coefficient: 3.2
The estimate for compound 4 lay 0.20 log units below the measured number, and the stated range covers the measured number.
By their numbers in this assay, from the lowest: compound 3; then compounds 1 and 4 (each within the scatter of the next).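

Until now this position had shown only one large drop, on going to 3-oxomorpholin-4-yl. In this assay, the swap to 6-fluoropyridin-3-yl gives a number 1.40 log units higher from compound 3 to compound 4 (beyond the scatter), so the number at this position moves strongly in both directions, even though the leaving and entering groups have the same heavy-atom count. Two different aromatic rings can now be compared here, and they cannot be told apart in this measurement, with a number 0.30 log units higher from compound 1 to compound 4 (within the scatter); among the three compounds with numbers, 2-methyl-1,3-oxazol-4-yl and 6-fluoropyridin-3-yl stand together, while the non-aromatic 3-oxomorpholin-4-yl stands apart.

Three compounds cannot show whether that split follows the aromatic ring itself or some other difference between the groups, and a morpholin-4-yl group without the carbonyl, or a plain phenyl ring, at the same place would separate these readings. Compound 2 has no number, so any effect of the configuration on this read-out remains unknown, and that pair would otherwise isolate it: the fact that compounds 2 and 4 differ only in the configuration as drawn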